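Trading a Hydroxypentyl Chain for an Aromatic Ring

This account rests on a few compounds, and the source may have more. Where it says the series, first, only, none or still open, it means among the compounds named here.

Compound 1 (`COc1cc(NC(C)CCCNC(=O)NNC(=O)NCCCCCO)c2ncccc2c1`) has been tested in a functional assay on SW-620 cells (Homo sapiens) for inhibition, read by MTT assay, with a stated time of 4 days (on this read-out higher numbers stand for weaker inhibition and lower numbers for stronger inhibition), where compound 1 gives > 100000 nM. That figure is a limit of the assay and not a number. Compound 2 (`CCOC(=O)NC(c1ccccc1)c1ccc(Cl)cc1`) gives > 100000 nM, which is also a limit. Compound 3 (`COc1cc(NC(C)CCCNC(=O)N(C)C(c2ccccc2)c2ccccc2)c2ncccc2c1`) is built on the core of compound 1. Here compound 3 gives > 100000 nM, again a limit. All the readings so far are therefore the same: the limit of > 100000 nM in this assay, at which 3 of the 3 values shown sit. Compound 1 thus has no exact position, and the three compounds cannot be ranked.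

Compound 4 (`COc1cc(NC(C)CCCNC(=O)Nc2ccc(Cl)c(C(F)(F)F)c2)c2ncccc2c1`) keeps the core of compound 1 and changes one place: 4-chloro-3-(trifluoromethyl)phenyl in place of ((5-hydroxypentyl)carbamoyl)amino on an amide-type nitrogen. In words, 4-chloro-3-(trifluoromethyl)phenyl stands in place of ((5-hydroxypentyl)carbamoyl)amino on an amide-type nitrogen. For the measured compounds named here, no measured pair yet shows what a single change does in this set, so any forecast is loose. The shared core offers no encouragement by itself, since compound 3 also reads > 100000 nM. Even so, this is a large change in the group, and a modest move is the likelier outcome. In this assay the expected step, toward stronger inhibition, is an at least 5.0-fold lower number from compound 1 to compound 4 (0.69 log units; beyond the scatter), an estimate resting on a starting point that is only a limit. For compound 4 the estimated value is 20000 nM, with an expected range from 4000 nM to 100000 nM.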

Compound 4, half-maximal inhibitory concentration: 23000 nM
Beside the measured number, compound 4's estimate is 1.2-fold (0.06 log units) below it; measured number inside the range.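

The swap on the shared core has a clear effect: in this assay, putting 4-chloro-3-(trifluoromethyl)phenyl in place of ((5-hydroxypentyl)carbamoyl)amino on an amide-type nitrogen gives an at least 4.3-fold lower number from compound 1 to compound 4 (0.63 log units; beyond the scatter). Compound 1 gives > 100000 nM, which is a limit of the assay and not a number. For the compounds shown here, this is the first sign that the group on this nitrogen can change the reading at all, and compound 4, at 23000 nM, is the only compound here with an exact position, while the others cannot be placed on the scale: the limit of > 100000 nM in this assay, at which 3 of the 4 values shown sit.

The change removes a chain with its carbonyl and brings in a ring with its chlorine and trifluoromethyl group all at once, so the compounds shown do not tell which of these parts accounts for the step. A cyclohexyl ring or an unsubstituted pyridine ring on the same nitrogen would help separate the part played by the ring itself from that of its two substituents.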